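A few compounds are considered here, and "the series" means these few. Any claim that something is new, unique, unknown or untested is made for them only; others in the source may bear on it.

In a functional assay on MCF cells (Homo sapiens) for antiproliferative activity, with a stated time of 72 h (a lower number here means a stronger inhibitor, a higher number a weaker inhibitor), compound 1 (`OC[C@H]1O[C@@H](n2cnc3c(NCc4ccc(Cl)cc4Cl)ncnc32)[C@H](O)[C@@H]1O`) gives 127000 nM. Compound 2 (`OC[C@H]1O[C@@H](n2cnc3c(NCc4ccc(F)c(F)c4F)ncnc32)[C@H](O)[C@@H]1O`) gives > 166000 nM, which is a limit of the assay and not a number. Compound 3 (`OC[C@H]1O[C@@H](n2cnc3c(NCc4cc(O)cc(O)c4)ncnc32)[C@H](O)[C@@H]1O`) differs from compound 2 in one place: 3,5-dihydroxyphenyl in place of 2,3,4-trifluorophenyl on a saturated chain carbon bound to a nitrogen on an aromatic ring. For the measured compounds named here, only one measured step bears on this change, an at least 1.3-fold higher number from compound 1 to compound 2 (0.11 log units; that floor lies within the scatter). It involves no hydroxy-bearing ring and gives no direction, so no clear change is expected in this assay. The estimated step, an at least 1.2-fold lower number from compound 2 to compound 3 (0.10 log units; that floor lies within the scatter), is expected to stay within the scatter. Compound 3 is expected at 130000 nM, within an estimated range of 50000 nM to 300000 nM.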

Compound 3, half-maximal inhibitory concentration: > 166000 nM
Compound 3: no number, only a limit (the forecaster's own chance of this, stated with the estimate: 45%); middle value at least 1.2-fold (0.10 log units) from the limit.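

With 3,5-dihydroxyphenyl on a saturated chain carbon bound to a nitrogen on an aromatic ring, a ring with hydrogen-bond donors joins the fluorinated ring of compound 2 at the limit of this assay. Against the 2,4-dichlorophenyl group, the change gives an at least 1.3-fold higher number from compound 1 to compound 3 (0.11 log units; that floor lies within the scatter). The step between compound 2 and compound 3 cannot be read, as both values are limits, so this position is seen only at the edge of the assay: the limit of > 166000 nM in this assay, at which 2 of the 3 values shown sit.

On these data alone, whether either ring differs from the other beyond that limit stays open. So does whether an amine, a carboxylic acid or a longer chain at this place would give a value that can be read.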